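Swapping the methoxyphenyl arm for a dichlorophenyl arm

This account rests on a few compounds, and the source may have more. Where it says the series, first, only, none or still open, it means among the compounds named here.

Two members of this series share one core and differ only in one aryl arm. In a functional assay on MCF7 cells (Homo sapiens) for cytotoxicity, read by MTT assay, with a stated time of 72 h (a lower number here means a stronger inhibitor, a higher number a weaker inhibitor), compound 1 `COc1cccc(/C=C2\CCC/C(=C\c3ccc(Cl)cc3)C2=O)c1OC` gives 10300 nM. Compound 2 `COc1ccc(/C=C2\CCC/C(=C\c3cccc(OC)c3OC)C2=O)cc1` gives 18600 nM in this assay. Of these two numbers compound 2 has the higher one, yet the step of a 1.8-fold higher number from compound 1 to compound 2 (0.26 log units; within the scatter) lies within the scatter, so the two compounds cannot be told apart. Compound 3 `COc1cccc(/C=C2\CCC/C(=C\c3cc(Cl)cc(Cl)c3)C2=O)c1OC` is not yet measured; compared with compound 2 the change is 3,5-dichlorophenyl in place of 4-methoxyphenyl on a double-bonded chain carbon bound to a double-bonded ring carbon. For the measured compounds named here, the only measured step that bears on this is a 1.8-fold higher number from compound 1 to compound 2 (0.26 log units; within the scatter), where methoxy in place of chloro on an aromatic carbon made no difference beyond the scatter. Going back toward chloro, now as 3,5-dichlorophenyl, therefore suggests at most a small move toward a lower number. Compound 3 is expected to give about 8000 nM, with a range from 3000 nM to 22000 nM. The step of a 2.3-fold lower number from compound 2 to compound 3 (0.37 log units; beyond the scatter) is expected to stay close to the scatter.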

Compound 3, half-maximal inhibitory concentration: 4300 nM
Beside the measured number, compound 3's estimate is 1.9-fold (0.27 log units) above it, within the range that was stated.
By their numbers in this assay, from the lowest: compound 3; then compounds 1 and 2 (each within the scatter of the next).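

In this assay, for the compounds shown here, the change to a 3,5-dichlorophenyl arm on a double-bonded chain carbon bound to a double-bonded ring carbon gives the first step in this set that clears the scatter: a 4.3-fold lower number from compound 2 to compound 3 (0.64 log units; beyond the scatter). The second comparison, a 2.4-fold lower number from compound 1 to compound 3 (0.38 log units; beyond the scatter), is also beyond the scatter, so this position does respond to the choice of aryl arm, and 3,5-dichlorophenyl stands apart from both 4-methoxyphenyl and 4-chlorophenyl, two arms that the earlier pair could not separate. No evidence is available to explain this difference.

The compounds shown leave open whether the lower number follows from chlorine itself or from the 3,5-dichloro arrangement. They also leave open how an aryl arm carrying an amine or a carboxylic acid would read here, and whether the step holds when the other arm on the shared core changes.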